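Adding a Methoxy Group to the Phenyl Ring

A few compounds are considered here, and "the series" means these few. Any claim that something is new, unique, unknown or untested is made for them only; others in the source may bear on it.

Of the compounds shown here, three sharing one core have been tested in a functional assay on PANC-1 cells (Homo sapiens) for inhibition, read by MTT assay, with a stated time of 24 h; on this read-out lower numbers stand for stronger inhibition and higher numbers for weaker inhibition. Compound 1 `CC1(C)[C@H]2CC[C@]1(C)N(Cc1cn(-c3cccc(Cl)c3)nn1)C(=O)C2` gives 260 nM, compound 2 `CC1(C)[C@H]2CC[C@]1(C)N(Cc1cn(-c3ccccc3)nn1)C(=O)C2` gives 160 nM, and compound 3 `CC1(C)[C@H]2CC[C@]1(C)N(Cc1cn(-c3cccc(Br)c3)nn1)C(=O)C2` gives 90 nM. On these numbers compound 2 stands in the middle, and both compound 1 and compound 3 lie within the usual scatter of it. The step from compound 1 to compound 3 is a 2.9-fold lower number from compound 1 to compound 3 (0.46 log units; beyond the scatter).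

Compound 4 `COc1ccc(-n2cc(CN3C(=O)C[C@@H]4CC[C@@]3(C)C4(C)C)nn2)cc1` has not yet been tested. Its change from compound 2 is methoxy in place of hydrogen on an aromatic carbon.

Within the data shown here, the steps that bear on this change are the two that alter the same ring position of compound 2: a 1.6-fold lower number from compound 1 to compound 2 (0.21 log units; within the scatter) and a 1.8-fold lower number from compound 2 to compound 3 (0.25 log units; within the scatter). Both stay within the scatter, so this position has so far tolerated a halogen or a hydrogen without a clear effect. Among the measured compounds shown here, no measured compound carries a methoxy group, so the expectation rests on that tolerance alone. In this assay compound 4 is therefore expected to give about 170 nM, within a range of 60 nM to 450 nM, an expected step of a 1.1-fold higher number from compound 2 to compound 4 (0.03 log units; within the scatter).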

Compound 4, half-maximal inhibitory concentration: 330 nM
Compound 4: middle estimate off by 1.9-fold (0.29 log units), on the low side; the measured number falls inside the stated range.
By their numbers in this assay, from the lowest: compounds 3, 2, 1 and 4 (each within the scatter of the next, the first and the last beyond it).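

In this assay, among these compounds, the 4-methoxyphenyl group brings a 2.1-fold higher number from compound 2 to compound 4 (0.31 log units; beyond the scatter) and is the first change from plain phenyl to lie beyond the usual scatter, so this ring does not take every substituent without effect, although the step is modest. Set against the halogen compounds, the picture splits: the 3-bromophenyl group gives a 3.7-fold higher number from compound 3 to compound 4 (0.56 log units; beyond the scatter) while the 3-chlorophenyl group gives a 1.3-fold higher number from compound 1 to compound 4 (0.10 log units; within the scatter) and stays within the scatter. No measurement shown gives a reason for these steps.

The compounds shown do not separate the effect of the methoxy group itself from that of its place on the ring, as the halogens are on 3-substituted phenyl rings and the methoxy group is para to a large group. As far as these compounds go, how an amine, a carboxylic acid or a longer chain such as ethoxy would fare at this place also remains open.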